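The source may hold more compounds than are shown below. What is called first, only, known or untested is meant among the compounds shown, and "the series" means these compounds.

Three compounds share one core and have been measured in a functional assay on MCF7 cells (Homo sapiens) for cytotoxicity, read by sulforhodamine B assay, with a stated time of 48 h; a lower number here means a stronger inhibitor, a higher number a weaker inhibitor:

compound 1 `CC1=C(/C=C/C(=O)/C=C/c2ccc(Cl)cc2)C(C)(C)CCC1`: 10200 nM
compound 2 `CC1=C(/C=C/C(=O)/C=C/c2ccc([N+](=O)[O-])cc2)C(C)(C)CCC1`: 5500 nM
compound 3 `CC1=C(/C=C/C(=O)/C=C/c2ccc(Cl)c(Cl)c2)C(C)(C)CCC1`: 53500 nM

Among these three numbers compound 1 stands second highest. The step of a 1.9-fold lower number from compound 1 to compound 2 (0.27 log units; within the scatter) lies within the scatter, so the values of compound 1 and compound 2 cannot be told apart. The step of a 5.2-fold higher number from compound 1 to compound 3 (0.72 log units; beyond the scatter) is a modest weakening and lies beyond the scatter.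

Compound 4 `CC1=C(/C=C/C(=O)/C=C/c2cccnc2)C(C)(C)CCC1` has not yet been measured. It differs from compound 1 by pyridin-3-yl in place of 4-chlorophenyl on a double-bonded chain carbon bound to a double-bonded chain carbon. Among the compounds with values here, no measured step replaces one aromatic ring by another: the change from compound 1 to compound 2 swaps one ring substituent for another, and the change from compound 1 to compound 3 adds a second substituent. Both bear only loosely on the change to compound 4. The first shows that a different group at that end of the chain leaves the number about unchanged; the second shows that a further alteration of that ring can raise it modestly. Compound 4 is therefore expected to give a number near that of compound 1, with a slight tilt towards a higher one. The expected step is a 1.5-fold higher number from compound 1 to compound 4 (0.17 log units; within the scatter). Compound 4 is thus estimated at 15000 nM, with a range from 5000 nM to 45000 nM.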

Compound 4, half-maximal inhibitory concentration: 15500 nM
Compound 4: middle estimate off by 1.0-fold (0.01 log units), on the low side; low and high end bracket the measured number.
By their numbers in this assay, from the lowest: compounds 2, 1 and 4 (each within the scatter of the next, the first and the last beyond it); then compound 3.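

In this assay, the step on replacing 4-chlorophenyl with pyridin-3-yl on a double-bonded chain carbon bound to a double-bonded chain carbon is a 1.5-fold higher number from compound 1 to compound 4 (0.18 log units; within the scatter). This shows that this place tolerates an exchange of the whole aromatic ring, not only of a substituent on it, without a difference that can be told from the scatter, even though the chlorine leaves, a ring nitrogen enters and the hydrogen-bond acceptor count goes from 0 to 1. Nothing available bears on why the two compounds give such similar numbers.

The step from compound 1 to compound 4 combines the loss of the chlorine with the entry of the ring nitrogen, and an unsubstituted phenyl at this place would be needed to separate the two. On these data alone, whether the ring nitrogen's location matters, as a pyridin-4-yl would show, and how a ring carrying an amine or a carboxylic acid would behave also remain open.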